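Phenoxy to dimethylamino on the aryl of compound 2

This account rests on a few compounds, and the source may have more. Where it says the series, first, only, none or still open, it means among the compounds named here.

For the measured compounds named here, compound 2 `Cc1cc(O)cc(-c2nn(CC#N)cc2-c2ccnc(-c3ccc(Oc4ccccc4)cc3)c2)c1` gives the only number: in a functional assay on UACC-62 cells (Homo sapiens) for inhibition, read by sulforhodamine B assay, with a stated time of 48 h (a lower number here means that less compound is tolerated, a higher number that more compound is tolerated), compound 2 gives 44400 nM. Compound 1 `COc1cc(C)cc(-c2c(-c3ccnc(-c4ccc(C(C)=O)cc4)c3)cnn2CC#N)c1` sits at the limit of this assay, reported as > 100000 nM; only that limit is known for it (the limit of > 100000 nM in this assay, at which 1 of the 2 values shown sits). Compound 3 `Cc1cc(O)cc(-c2nn(CC#N)cc2-c2ccnc(-c3ccc(N(C)C)cc3)c2)c1` differs from compound 2 by dimethylamino in place of phenoxy on an aromatic carbon. Going by the values given here, no measured step covers such a change, so the expected step of a 1.1-fold higher number from compound 2 to compound 3 (0.05 log units; within the scatter) is taken as none beyond the scatter, in either direction. Compound 3 is estimated at 50000 nM, within 15000 nM to 150000 nM.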

Compound 3, concentration lethal to 50% of the cells: 72100 nM
Beside the measured number, compound 3's estimate is 1.4-fold (0.16 log units) below it; measured number inside the range.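

Dimethylamino in place of phenoxy on this aromatic carbon, para to a large group, gives a 1.6-fold higher number from compound 2 to compound 3 (0.21 log units; within the scatter) in this assay. The six-membered aromatic ring of phenoxy is therefore not needed to keep the number at this level, since the smaller dimethylamino group reads the same within the scatter. No measured property in hand bears on this step. From the compounds shown here alone, what a carboxylic acid or a primary amine would give at this position stays open. Going by these compounds, whether any group here can move the number beyond the scatter also stays open.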